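The compounds below may be only part of what the source reports. "The series", "measured", "known", "first", "only" and "open" are said of these compounds alone.

Measured in a functional assay on U-937 cells (Homo sapiens) for inhibition, read by MTT assay, with a stated time of 72 h; a higher number here means a weaker inhibitor, a lower number a stronger inhibitor:
- Compound 1 `Nc1ccccc1NC(=O)c1ccc(CNCc2nc(-c3ccc(Cl)cc3)no2)cc1`: 430 nM
- Compound 2 `O=C(NO)c1ccc(CNCc2nc(-c3ccccc3)no2)cc1`: 7210 nM
- Compound 3 `O=C(NO)c1ccc(CNCc2nc(-c3ccc(C(F)(F)F)cc3)no2)cc1`: 8050 nM

Compound 3, at 8050 nM, sits level with compound 2 within the scatter, and its number is well above that of compound 1. Compound 4 `O=C(NO)c1ccc(CNCc2nc(-c3ccc(Cl)cc3)no2)cc1` differs from compound 3 as follows: chloro in place of trifluoromethyl on an aromatic carbon. Going by the values given here, the one measured step at this spot is a 1.1-fold higher number from compound 2 to compound 3 (0.05 log units; within the scatter), a change that lies within the scatter. Compound 1 carries the same chloro but differs elsewhere, so its 430 nM cannot isolate this swap. The expected change is a 1.2-fold lower number from compound 3 to compound 4 (0.06 log units; within the scatter), with no shift beyond the scatter in either direction. For compound 4 the estimated value is 7000 nM, within an expected range of 3500 nM to 14000 nM.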

Compound 4, half-maximal inhibitory concentration: 5290 nM
For compound 4 the middle estimate is 1.3-fold (0.12 log units) above the measured one; the measured number falls inside the stated range.
By their numbers in this assay, from the lowest: compound 1; then compounds 4, 2 and 3 (each within the scatter of the next).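

In this assay, trifluoromethyl to chloro on this aromatic carbon gives a 1.5-fold lower number from compound 3 to compound 4 (0.18 log units; within the scatter) and hydrogen to chloro gives a 1.4-fold lower number from compound 2 to compound 4 (0.13 log units; within the scatter), so all three groups sit level here. With chloro held fixed, hydroxy in place of 2-aminophenyl on the amide-type nitrogen gives a 12-fold higher number from compound 1 to compound 4 (1.09 log units; beyond the scatter), so the clear change in the number comes at that nitrogen, not at this carbon. No measurement at hand explains either result. Going by these compounds, whether an amine or a carboxylic acid on this aromatic carbon would shift the number stays open. So does whether the 2-aminophenyl compounds would respond to hydrogen or trifluoromethyl here as the hydroxy compounds do.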